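This account rests on a few compounds, and the source may have more. Where it says the series, first, only, none or still open, it means among the compounds named here.

Compound 1 `CSc1nc(N)c2ccn(COCCO)c2n1` is one of two compounds of the shared core tested in a functional assay on BSC-1 cells (Cercopithecidae) for cytotoxicity; on this read-out higher numbers stand for weaker inhibition and lower numbers for stronger inhibition. In this assay compound 1 gives > 100000 nM, which is a limit of the assay and not a number. Compound 2 `Nc1nc(O)nc2c1ccn2COCCO` carries a hydroxy in place of the methylsulfanyl on an aromatic carbon. In this assay compound 2 gives > 100000 nM, again a limit of the assay and not a number. The step between them is therefore a step that the two limits leave unreadable from compound 1 to compound 2. Both values sit at the limit of > 100000 nM in this assay, at which 2 of the 2 values shown sit, so no readable step exists within this core so far.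

Compound 3 `Nc1nc(Cl)nc2c1ccn2COCCO` has not yet been measured. Its difference from compound 1 is chloro in place of methylsulfanyl on an aromatic carbon. Within the data shown here, the only measured step, with its unreadable size, gives no guide to direction or magnitude; what the numbers show is only that both measured compounds sit at the limit of > 100000 nM in this assay, at which 2 of the 2 values shown sit. Compound 3 is therefore expected to stay at the limit as well, with an expected step of a number no higher from compound 1 to compound 3 (the limit leaves the size open) in this assay. The estimate for compound 3 in this assay is 100000 nM, with a range from 30000 nM to 300000 nM.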

Compound 3, half-maximal inhibitory concentration: > 100000 nM
Compound 3: only a limit was reported; the forecaster's own chance of this, stated with the estimate: 85%; the middle value lies on the limit itself.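

The steps from compound 3 to compound 1 and compound 2 cannot be read, as all three compounds stay at a limit of this assay and not at a number: the limit of > 100000 nM in this assay, at which 3 of the 3 values shown sit.

The compounds shown leave open how methylsulfanyl, hydroxy and chloro at this place on the shared core differ in this assay, as no readable value separates them.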